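Compound 4: replacing the benzyl group of compound 1

This account rests on a few compounds, and the source may have more. Where it says the series, first, only, none or still open, it means among the compounds named here.

In a functional assay on DU-145 cells (Homo sapiens) for inhibition, read by trypan blue exclusion, with a stated time of 96 h (a lower number here means a stronger inhibitor of growth, a higher number a weaker inhibitor of growth), compound 1 (`O=C(O)c1ccc(C(=O)/C(=C\c2ccc(F)c([N+](=O)[O-])c2)SCc2ccc(Cl)cc2Cl)cc1`) gives 1000 nM. Going by the values given here, compound 2 (`CN(C)c1ccc(/C=C(/SCc2ccc(Cl)cc2)C(=O)c2ccc(C(=O)O)cc2)cc1`) gives 1000 nM, level with compound 1, and together they hold the lowest number of the three measured so far. Compound 3 (`O=C(/C(=C\c1ccc(O)c([N+](=O)[O-])c1)S(=O)(=O)Cc1ccc(Br)cc1)c1c(F)c(F)c(F)c(F)c1F`) gives 50000 nM, higher than compound 1 by a margin well beyond the scatter.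

The next compound for this assay is compound 4 (`O=C(O)c1ccc(C(=O)/C(=C\c2ccc(F)c([N+](=O)[O-])c2)SCc2ccc(C(F)(F)F)cc2)cc1`). It differs from compound 1 by one change, 4-(trifluoromethyl)phenyl in place of 2,4-dichlorophenyl on a saturated chain carbon bound to a sulfur. Among the compounds with values here, no measured pair isolates this change, so there is no direct precedent for its size or direction. The working expectation is therefore no step beyond the scatter, with the reading anchored on compound 1 at 1000 nM. The estimated change is no change at the digits printed from compound 1 to compound 4 (within the scatter). For compound 4 the expected value is 1000 nM, with an estimated range of 300 nM to 3500 nM.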

Compound 4, concentration for 50% growth inhibition: 1000 nM
Estimate against measurement, compound 4: no gap at the digits printed; measured number inside the range.
By their numbers in this assay, from the lowest: compounds 1, 2 and 4 (each within the scatter of the next); then compound 3.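

In this assay, going by these compounds alone, the exchange of 2,4-dichlorophenyl for 4-(trifluoromethyl)phenyl on a saturated chain carbon bound to a sulfur reads no change at the digits printed from compound 1 to compound 4 (within the scatter), giving the only single-place comparison so far. At this place, an aromatic ring with two chlorines and 8 heavy atoms and one with a trifluoromethyl group and 10 heavy atoms therefore give readings within the scatter of each other, so this pair shows no sensitivity to the exchange. Nothing in the available data accounts for this reading.

On these data alone, whether the same holds for an unsubstituted benzyl, a benzyl carrying an amine, or a longer chain such as phenethyl at this place remains open. The sulfone of compound 3 also remains unresolved, since compound 3 differs from compound 1 in more than one place.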